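The source may report more compounds than this note shows. Statements on the series, on what has been measured and on what is new or still open speak of the compounds shown alone.

Working notes on the series. The shared core carries a trifluoromethyl group and a chloro substituent; compound 1 `O=C(Nc1ccc(F)cc1)OCC1(C(F)(F)F)OC(=O)Nc2ccc(Cl)cc21` bears a carbamate link to a 4-fluorophenyl ring, while compound 2 `O=C1Nc2ccc(Cl)cc2C(CNC(=O)c2cccc(F)c2)(C(F)(F)F)O1` carries an amide to a 3-fluorophenyl ring. In an assay for inhibition of very long chain fatty acid elongase 6 (Homo sapiens) (a higher number here means a weaker inhibitor, a lower number a stronger inhibitor), compound 1 gives 142 nM and compound 2 gives 261 nM. The two compounds differ in more than one place, so no single step can be read between them; their two numbers in this assay lie within the usual scatter of each other, and nothing about order between them can be claimed.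

Compound 3 `Cc1ccccc1C(=O)NCC1(C(F)(F)F)OC(=O)Nc2ccc(Cl)cc21` is not yet measured. It changes compound 2 in one place: 2-methylphenyl in place of 3-fluorophenyl on a carbonyl carbon. Going by the values given here, no measured pair shows the effect of this exchange, so the expectation rests only on the values at hand. A step of a 1.1-fold higher number from compound 2 to compound 3 (0.06 log units; within the scatter) is expected, that is, none beyond the scatter in either direction. Compound 3 is therefore estimated at 300 nM in this assay, with a range from 120 nM to 750 nM.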

Compound 3, half-maximal inhibitory concentration: 971 nM
Beside the measured number, compound 3's estimate is 3.2-fold (0.51 log units) below it; measured number outside the range, above it.
By their numbers in this assay, from the lowest: compounds 1 and 2 (each within the scatter of the next); then compound 3.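

Going by these compounds alone, this is the first step that can be read at one place: on a carbonyl carbon whose other neighbour is an amide-type nitrogen, 2-methylphenyl in place of 3-fluorophenyl gives a 3.7-fold higher number from compound 2 to compound 3 (0.57 log units; beyond the scatter) in this assay, so the number in this assay responds to the group held at this position. The response appears even though the two groups match in everything counted apart from the element make-up: the same number of heavy atoms, one six-membered aromatic ring of carbon only, no hydrogen-bond donors or acceptors, and no net charge. The step from compound 1 to compound 3 cannot be read, as those two differ in more than one place, and nothing at hand bears on the reason for the step seen here.

The exchange removes fluorine and brings in methyl in a single move, so the step cannot be assigned to either change alone; unsubstituted phenyl, 2-fluorophenyl or 3-methylphenyl on the same carbonyl would separate the two. Also open, from the compounds shown here alone, is how this position answers to a ring carrying an amine or a carboxylic acid, and whether the step carries over to the carbamate link of compound 1.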